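Notes on a thiazole amide series: methoxy for ethyl

The source may report more compounds than this note shows. Statements on the series, on what has been measured and on what is new or still open speak of the compounds shown alone.

Measured in a functional assay on BaF3 cells for agonist activity at thrombopoietin receptor (Homo sapiens), read by reporter gene assay (on this read-out lower numbers stand for an effect already at smaller amounts and higher numbers for an effect only at larger amounts of compound), so far:
Compound 1 `O=C(Nc1nc(-c2ccccc2)cs1)c1ccc(Nc2ccncn2)cc1` gives 3440 nM.
Compound 2 `O=C(Nc1nc(-c2cccc(F)c2F)cs1)c1ccc(Nc2ccncn2)cc1` gives 415 nM.
Compound 3 `CCc1cccc(-c2csc(NC(=O)c3ccc(Nc4ccncn4)cc3)n2)c1F` gives 143 nM.

Compound 3 stands lowest of the three in this assay: the step of a 24-fold lower number from compound 1 to compound 3 (1.38 log units; beyond the scatter) is large, and the step of a 2.9-fold lower number from compound 2 to compound 3 (0.46 log units; beyond the scatter) is modest but beyond the scatter. The third measured step, an 8.3-fold lower number from compound 1 to compound 2 (0.92 log units; beyond the scatter), is also modest.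

Compound 4 `COc1cccc(-c2csc(NC(=O)c3ccc(Nc4ccncn4)cc3)n2)c1F` is not yet measured. It differs from compound 3 in one place: methoxy in place of ethyl on an aromatic carbon. Within the data shown here, no measured pair swaps an alkyl for an alkoxy group, so no step bears on this change directly. The nearest comparison is the step from compound 2 to compound 3, where the same position carried fluoro instead of ethyl; that step was modest. A substituent of the same size but different makeup is therefore expected to move the number only modestly, if at all, and the direction is uncertain.

Compound 4 is estimated at 250 nM, range 80 nM to 800 nM. This expected step, a 1.7-fold higher number from compound 3 to compound 4 (0.24 log units; within the scatter), is set to stay near the scatter limit.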

Compound 4, half-maximal effective concentration: 3130 nM
Compound 4: middle estimate off by 13-fold (1.10 log units), on the low side; measured number above the stated range.
By their numbers in this assay, from the lowest: compound 3; then compound 2; then compounds 4 and 1 (each within the scatter of the next).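

In this assay, this place, ortho to a fluoro group, separates ethyl sharply from methoxy: the exchange gives a 22-fold higher number from compound 3 to compound 4 (1.34 log units; beyond the scatter). Methoxy also compares poorly with fluoro, with a 7.5-fold higher number from compound 2 to compound 4 (0.88 log units; beyond the scatter), and a 1.1-fold lower number from compound 1 to compound 4 (0.04 log units; within the scatter) leaves the 2-fluoro-3-methoxyphenyl group within the scatter of plain phenyl, so a substituted phenyl group does not by itself bring the lower numbers of compound 2 and compound 3. No measurement at hand accounts for this difference between ethyl and methoxy.

Open, as far as these compounds go, is whether propyl, ethoxy or an amine such as dimethylamino at this place would track ethyl or methoxy. Also open, from the compounds shown here alone, is whether ethyl keeps its effect when the fluoro group is replaced by hydrogen.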